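Shortening the terminal chain of a diyne alcohol

The source may report more compounds than this note shows. Statements on the series, on what has been measured and on what is new or still open speak of the compounds shown alone.

Compound 1 `C=CCCCCCC#CC#CC(O)CC(C)=O`: 3.42 ug/mL
Compound 2 `C=CCCCCCCCC#CC#CC(O)CC(C)=O`: 4.18 ug/mL
Compound 3 `C=CCCCCCCCC#CC#CCO`: 3.32 ug/mL

These three compounds were tested in a functional assay on HCT-15 cells (Homo sapiens) for cytotoxicity; on this read-out lower numbers stand for an effect already at smaller amounts and higher numbers for an effect only at larger amounts of compound. Compound 2 sits within the usual scatter of both its neighbours: the step of a 1.2-fold higher number from compound 1 to compound 2 (0.09 log units; within the scatter) and the step of a 1.3-fold lower number from compound 2 to compound 3 (0.10 log units; within the scatter) are each too small to count as a real change, so none of the three can be called more or less potent than another.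

Compound 4 `CCCCCCCC#CC#CC(O)CC(C)=O` differs from compound 2 by hydrogen in place of vinyl on a saturated chain carbon, seven bonds along the chain from a triple-bonded carbon. Within the data shown here, the step that most resembles it is the one from compound 1 to compound 2, which also altered the end of the chain far from the triple-bonded carbons and gave a 1.2-fold higher number from compound 1 to compound 2 (0.09 log units; within the scatter), a difference within the scatter. The other known step, a 1.3-fold lower number from compound 2 to compound 3 (0.10 log units; within the scatter), touched the opposite end of the molecule and was likewise within the scatter. With both known changes leaving the read-out essentially unchanged, no step beyond the scatter is expected for a 1.1-fold higher number from compound 2 to compound 4 (0.03 log units; within the scatter). Compound 4 is therefore estimated at 4.5 ug/mL, with a likely range from 2.2 ug/mL to 9 ug/mL.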

Compound 4, concentration for half-maximal effect: 3.73 ug/mL
The estimate for compound 4 lay 1.2-fold (0.08 log units) above the measured number; the measured number falls inside the stated range.
By their numbers in this assay, from the lowest: compounds 3, 1, 4 and 2 (each within the scatter of the next).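

In this assay, among these compounds, the earlier compounds all carried the vinyl group, so they could not show what happens without it. Hydrogen in place of vinyl, on a saturated chain carbon seven bonds along the chain from a triple-bonded carbon, gives a 1.1-fold lower number from compound 2 to compound 4 (0.05 log units; within the scatter), so removing this group and its double bond leaves no real change in the read-out. The same holds against the shorter alkene, with ethyl in place of vinyl giving a 1.1-fold higher number from compound 1 to compound 4 (0.04 log units; within the scatter), and no supporting measurement is available to explain this flat result.

The compounds shown leave open whether an amine or a carboxylic acid in place of the vinyl group would produce a step beyond the scatter. They also leave open whether a much longer chain would do so, since every step seen so far lies within it.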